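Swapping the aryl group on a chlorinated core

This account rests on a few compounds, and the source may have more. Where it says the series, first, only, none or still open, it means among the compounds named here.

- Compound 1 `COc1ccccc1Oc1c(N)nc(-c2ccc(C)cc2)nc1Cl`: 17400 nM
- Compound 2 `COc1ccccc1Oc1c(N)nc(-c2cccc(Cl)c2)nc1Cl`: 17900 nM

In a functional assay on B16 cells (Mus musculus) for cytotoxicity, read by CCK-8 assay, with a stated time of 24 h (on this read-out higher numbers stand for weaker inhibition and lower numbers for stronger inhibition), compound 2 gives 17900 nM, level with compound 1 at 17400 nM. Compound 3 `COc1ccccc1Oc1c(N)nc(-c2ccc(Br)cc2)nc1Cl` differs from compound 2 by one change: 4-bromophenyl in place of 3-chlorophenyl on an aromatic carbon. Among the compounds with values here, the only measured step at this place on the core, a 1.0-fold higher number from compound 1 to compound 2 (0.01 log units; within the scatter), stayed within the scatter. No step beyond the scatter is therefore expected in this assay. The expected change is a 1.1-fold lower number from compound 2 to compound 3 (0.05 log units; within the scatter). For compound 3 the estimated value is 16000 nM, with an expected range of 8000 nM to 30000 nM.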

Compound 3, half-maximal inhibitory concentration: 4440 nM
Estimate against measurement, compound 3: 3.6-fold (0.56 log units) above; the measured number lies below the stated range.
By their numbers in this assay, from the lowest: compound 3; then compounds 1 and 2 (each within the scatter of the next).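

In this assay, the aryl group at this position on the shared core can clearly shift the number: 4-bromophenyl in place of 3-chlorophenyl gives a 4.0-fold lower number from compound 2 to compound 3 (0.61 log units; beyond the scatter) and bromo in place of methyl gives a 3.9-fold lower number from compound 1 to compound 3 (0.59 log units; beyond the scatter). Compound 1 and compound 2 alone had shown no step beyond the scatter here. Nothing available explains why compound 3 stands apart.

As far as these compounds go, compound 3 differs from compound 2 in both the halogen and its place on the ring, so which of these counts stays open. From the compounds shown here alone, a 4-chlorophenyl group would help separate them, while a phenyl ring carrying an amine or a carboxylic acid remains unexplored here.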